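Removing the methyl and adding a second fluorine

A few compounds are considered here, and "the series" means these few. Any claim that something is new, unique, unknown or untested is made for them only; others in the source may bear on it.

Three compounds sharing one core were measured in an assay on Sf9 cells for inhibition of serine/threonine-protein kinase 4 (Homo sapiens), read by luminescence and ADP-Glo, with a stated time of 1 h, in the presence of a further agent that is not named here; a higher number here means a weaker inhibitor, a lower number a stronger inhibitor. Compound 1 `CN1C(=O)C(c2cccc(F)c2)N(C)c2nc(Nc3ccc(S(N)(=O)=O)cc3)ncc21` gives 134 nM. Compound 2 `CN1C(=O)C(c2ccccc2Br)N(C)c2nc(Nc3ccc(S(N)(=O)=O)cc3)ncc21` gives 57 nM. Compound 3 `Cc1c(F)cccc1C1C(=O)N(C)c2cnc(Nc3ccc(S(N)(=O)=O)cc3)nc2N1C` gives 419 nM, the highest of the three numbers: its step from compound 1 a 3.1-fold higher number from compound 1 to compound 3 (0.50 log units; beyond the scatter) and from compound 2 a 7.4-fold higher number from compound 2 to compound 3 (0.87 log units; beyond the scatter) both lie beyond the scatter.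

Compound 4 `CN1C(=O)C(c2c(F)cccc2F)N(C)c2nc(Nc3ccc(S(N)(=O)=O)cc3)ncc21` differs from compound 3 in one place: 2,6-difluorophenyl in place of 3-fluoro-2-methylphenyl on a saturated ring carbon. Among the compounds with values here, two measured steps bear on this change. The methyl that enters from compound 1 to compound 3 raised the number a 3.1-fold higher number from compound 1 to compound 3 (0.50 log units; beyond the scatter), and compound 4 drops that methyl again. The step of a 2.4-fold lower number from compound 1 to compound 2 (0.37 log units; beyond the scatter) shows that a substituent at the 2-position of the phenyl, there a bromine, went with a lower number. Within the data shown here, compound 4 carries fluorine at both the 2- and 6-positions, a pattern no measured compound shows, so the combined effect is uncertain.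

Compound 4 is therefore expected to return to or below the level of compound 1, a step of a 5.2-fold lower number from compound 3 to compound 4 (0.72 log units; beyond the scatter) that is estimated to lie beyond the scatter. The estimate for compound 4 in this assay is 80 nM, with a range from 30 nM to 250 nM.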

Compound 4, half-maximal inhibitory concentration: 42 nM
For compound 4 the middle estimate is 1.9-fold (0.28 log units) above the measured one; measured number inside the range.
By their numbers in this assay, from the lowest: compounds 4 and 2 (each within the scatter of the next); then compound 1; then compound 3.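

In this assay, exchanging 3-fluoro-2-methylphenyl for 2,6-difluorophenyl on the saturated ring carbon gives a 10-fold lower number from compound 3 to compound 4 (1.00 log units; beyond the scatter), the largest step among the four compounds, even though the group leaving and the group entering each count 8 heavy atoms. The 2,6-difluorophenyl group also separates from 3-fluorophenyl, with a 3.2-fold lower number from compound 1 to compound 4 (0.50 log units; beyond the scatter), whereas a 1.4-fold lower number from compound 2 to compound 4 (0.13 log units; within the scatter) leaves 2,6-difluorophenyl and 2-bromophenyl without any order at this position. Nothing further is available here to explain these differences.

The step between compound 3 and compound 4 replaces the whole phenyl group at once, so the compounds shown do not separate what the methyl and each fluorine contribute to it. Also open, going by these compounds, is how this saturated ring carbon would read in this assay with a phenyl group carrying an amine or a carboxylic acid, or with a longer chain in place of the phenyl group.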